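Mirror-image pyrrolidine amide and a weak sodium channel block

This account rests on a few compounds, and the source may have more. Where it says the series, first, only, none or still open, it means among the compounds named here.

Compound 1, `CC(C)(C)OC(=O)n1cc(-c2ccc(NC(=O)c3cc4ccccc4[nH]3)cc2)nc1N`: 28000 nM
Compound 2, `CC(C)(C)OC(=O)n1cc(-c2ccc(NC(=O)[C@@H]3CCCN3)cc2)nc1N`: > 30000 nM (a limit, not a number)

Of the compounds shown here, two have been measured in an assay on isolated protein for inhibition of sodium channel protein type 4 subunit alpha (Homo sapiens), read by electrophysiology, with a stated time of 4 min; a higher number here means a weaker inhibitor, a lower number a stronger inhibitor. Compound 1 gives 28000 nM. Compound 2 reaches only the limit of this assay, > 30000 nM, so for compound 2 a bound is known and nothing more. From the compounds shown here alone, the change from compound 1 to compound 2 put pyrrolidin-2-yl in place of 1H-indol-2-yl on the carbonyl carbon, giving an at least 1.0-fold higher number from compound 1 to compound 2 (0.02 log units; that floor lies within the scatter), and because the limit of > 30000 nM in this assay, at which 1 of the 2 values shown sits, the true size of that step stays open.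

Compound 3 (`CC(C)(C)OC(=O)n1cc(-c2ccc(NC(=O)[C@H]3CCCN3)cc2)nc1N`) is the unmeasured partner. (the two compounds have the same atoms and bonds and differ only in configuration as drawn: 1 of 1 stereo elements differ; a stereocentre at a saturated ring carbon is drawn S in compound 2 and R in compound 3). Among the compounds with values here, no measured step concerns a change in configuration alone, so the step from compound 1 to compound 2 bears on it only loosely. With compound 2 at the limit, compound 3 is expected to stay near it, with the step that the limit leaves unreadable from compound 2 to compound 3 expected to be none beyond the scatter. Compound 3 is therefore estimated at 35000 nM, within 15000 nM to 80000 nM, and most likely reported again as a limit.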

Compound 3, half-maximal inhibitory concentration: > 30000 nM
Compound 3 ended at the assay's limit; the forecaster's own chance of this, stated with the estimate: 70%; the middle value lies beyond the limit too.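

In this assay, the step between compound 2 and compound 3 cannot be read, because of what both values are: the limit of > 30000 nM in this assay, at which 2 of the 3 values shown sit. Neither drawn configuration of the pyrrolidin-2-yl group gives a readable number, and the test here concerns configuration alone: the fact that compounds 2 and 3 differ only in the configuration as drawn. With the R configuration, pyrrolidin-2-yl in place of 1H-indol-2-yl on the carbonyl carbon gives an at least 1.0-fold higher number from compound 1 to compound 3 (0.02 log units; that floor lies within the scatter), so this change again yields only a floor, with its true size unknown.

From the compounds shown here alone, whether configuration at this ring carbon matters at all for this channel stays open, and no value shown can settle it. Also open, going by these compounds, is how an open-chain amine or a carboxylic acid in place of pyrrolidin-2-yl on the carbonyl carbon would read in this assay.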